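Thiophen-2-yl for pyridin-2-yl on the hydrazone carbon

The source may hold more compounds than are shown below. What is called first, only, known or untested is meant among the compounds shown, and "the series" means these compounds.

Measured compounds in a physicochemical assay, with a stated time of 30 min; on this read-out higher numbers stand for weaker inhibition and lower numbers for stronger inhibition:
compound 1, `C/C(=N\N=C1/SCC(=O)N1Cc1cccc(Cl)c1)c1cccs1`: 20300000 nM
compound 2, `C/C(=N/N=C1\SCC(=O)N1Cc1ccc(F)cc1)c1ccccn1`: 16200000 nM
compound 3, `C/C(=N\N=C1/SCC(=O)N1Cc1cccc(Cl)c1)c1ccccn1`: 26800000 nM

Three compounds have numbers in this assay, and all three lie within the usual scatter of one another. Compound 3 and compound 1 share a core and differ in one place: thiophen-2-yl in place of pyridin-2-yl on a carbon with a double bond to nitrogen. This change gave a 1.3-fold lower number from compound 3 to compound 1 (0.12 log units; within the scatter), so it left the read-out essentially where it was.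

Compound 2 and compound 3 carry different cores; the difference between the two cores is not broken down here. Compound 4, `C/C(=N/N=C1\SCC(=O)N1Cc1ccc(F)cc1)c1cccs1`, has not yet been measured. It stands to compound 2 as compound 1 stands to compound 3: thiophen-2-yl in place of pyridin-2-yl on a carbon with a double bond to nitrogen. The place lines of the two changes agree word for word, so this is the same change made on the other core.

Among the measured compounds shown here, the only evidence for the size of the step is the pair compound 3 to compound 1, where it stayed within the scatter. The same is expected on the core of compound 2: the step from compound 2 to compound 4 is estimated as a 1.2-fold lower number from compound 2 to compound 4 (0.10 log units; within the scatter). On that basis compound 4 is expected to give 13000000 nM in this assay, with a range from 6000000 nM to 28000000 nM allowed because a single repeat of a change seen once, as in a 1.3-fold lower number from compound 3 to compound 1 (0.12 log units; within the scatter), carries little weight beyond the scatter itself.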

Compound 4, half-maximal inhibitory concentration: 21500000 nM
Compound 4: the middle estimate sits 1.7-fold (0.22 log units) below what was measured, and the stated range covers the measured number.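

In this assay, the replacement of pyridin-2-yl by thiophen-2-yl on a carbon with a double bond to nitrogen now has a reading on a second core: a 1.3-fold higher number from compound 2 to compound 4 (0.12 log units; within the scatter) stands alongside a 1.3-fold lower number from compound 3 to compound 1 (0.12 log units; within the scatter), and as both steps lie within the scatter, their opposite directions carry no weight. Among the compounds shown here, on these two pairs, the change gives no step that can be told from the scatter on either core, which is all that can be said to carry across; two pairs do not show that the same would hold on other cores, or that the two cores respond identically to this change. No measured information bears on the reason for this result.

From the compounds shown here alone, all four compounds carry a five- or six-membered aromatic ring with one hetero atom on that carbon, so it remains open how the read-out would respond to a carboxylic acid, an amine or a longer saturated chain there. Also open, going by these compounds, is whether a nitrile or a methoxy group in place of the chlorine or fluorine on the benzyl group would give a step beyond the scatter.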